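The source may report more compounds than this note shows. Statements on the series, on what has been measured and on what is new or still open speak of the compounds shown alone.

Compound 1 `NC1=NC2(CCSCC2)N(OCCCOc2cccc(Cl)c2)C(N)=N1` is tested in an assay on isolated protein for inhibition of Dihydrofolate reductase (Homo sapiens), read by spectrophotometry, using NADPH, with stated times of 5 s and 6 min, tested at 50 uM (a lower number here means a weaker effect, a higher number a stronger effect of the compound at the concentration tested), where compound 1 gives 88.8%. Compound 2 `NC1=NC2(CCOCC2)N(OCCCOc2cccc(Cl)c2Cl)C(N)=N1` gives 89.8% in this assay, a number within the usual scatter of that of compound 1, so the two are not told apart here. Compound 3 `NC1=NC2(CCSCC2)N(OCCCOc2cc(Cl)c(Cl)cc2Cl)C(N)=N1` differs from compound 1 in one place: 2,4,5-trichlorophenyl in place of 3-chlorophenyl on an oxygen on a saturated carbon. Within the data shown here, no step between measured compounds covers this change, so the expected step of a number 1.8 percentage points lower from compound 1 to compound 3 (within the scatter) is set to stay within the scatter, in no particular direction. Compound 3 is therefore expected to give about 87% in this assay, estimated between 74% and 95%.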

Compound 3, a percentage reported as inhibition, at one concentration (the size of the read-out at that concentration, not a potency): 94.4%
Estimate against measurement, compound 3: 7.4 percentage points below, within the range that was stated.
By their numbers in this assay, from the lowest: compounds 1, 2 and 3 (each within the scatter of the next).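

In this assay, 2,4,5-trichlorophenyl in place of 3-chlorophenyl on an oxygen on a saturated carbon gives a number 5.6 percentage points higher from compound 1 to compound 3 (within the scatter) and so shows that this position accepts the larger trichlorinated ring without a loss beyond the scatter. The two added chlorine atoms therefore produce no separable change at this concentration. No available evidence bears on this result. On these data alone, whether an unsubstituted phenyl, or a phenyl carrying an amine or a carboxylic acid, keeps this read-out remains open. Any difference in potency also remains open, as a single concentration gives no potency.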